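This account rests on a few compounds, and the source may have more. Where it says the series, first, only, none or still open, it means among the compounds named here.

Compound 1 `O=C(/C(=C\c1c(-c2ccccc2)[nH]c2ccccc12)S(=O)(=O)c1ccccc1)c1ccccc1`: 5000 nM in a functional assay on HOP-92 cells (Homo sapiens) for inhibition, read by sulforhodamine B assay, with a stated time of 48 h; on this read-out lower numbers stand for stronger inhibition of growth and higher numbers for weaker inhibition of growth
Compound 2 `COc1ccc(-c2[nH]c3ccc(OC)cc3c2/C=C(\C#N)S(=O)(=O)c2ccccc2)cc1`: 698 nM in this assay

Compound 1 has the highest number of the two; compound 2 shows the lower number, and the gap between them lies beyond the scatter. Compound 3 `N#C/C(=C\c1c(-c2ccccc2)[nH]c2ccccc12)S(=O)(=O)c1ccccc1` is not yet measured. It differs from compound 1 in one place: cyano in place of benzoyl on a double-bonded chain carbon bound to a double-bonded chain carbon and a sulfonyl sulfur. Compound 2 also bears a cyano group, but it differs from compound 3 in other respects too, so the gap between compound 1 and compound 2 can only hint at the direction. In this assay a step from compound 1 to compound 3 toward a lower number, beyond the scatter, is expected, about a 3.3-fold lower number from compound 1 to compound 3 (0.52 log units; beyond the scatter). Compound 3 is estimated at 1500 nM, within a range from 500 nM to 5000 nM.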

Compound 3, concentration for 50% growth inhibition: 10300 nM
Beside the measured number, compound 3's estimate is 6.9-fold (0.84 log units) below it; measured number above the stated range.
By their numbers in this assay, from the lowest: compound 2; then compound 1; then compound 3.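

Putting cyano in place of benzoyl on this double-bonded chain carbon, with the rest of the molecule unchanged, gives a 2.1-fold higher number from compound 1 to compound 3 (0.31 log units; beyond the scatter) in this assay. Going by these compounds alone, this modest step is the first direct reading at this position: the number responds to the change, and of these two groups benzoyl carries the lower number. Nothing at hand accounts for the step.

From the compounds shown here alone, how an amine, a carboxylic acid or a longer chain would read at this place remains open. So does whether the step keeps its direction on a different core.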